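The source may report more compounds than this note shows. Statements on the series, on what has been measured and on what is new or still open speak of the compounds shown alone.

Working notes on the thioacetamide series read in a functional assay on HT-29 cells (Homo sapiens) for cytotoxicity, read by MTT assay, with a stated time of 24 h, tested at 6.4 ug/mL; a lower number here means a weaker effect, a higher number a stronger effect of the compound at the concentration tested.

Compound 1 `Cn1c(-c2ccc(NC(=O)CSc3nc4ccccc4o3)cc2)nc(-c2ccccc2)c1-c1ccccc1` gives 44.9% in this assay. Compound 2 `Cn1c(-c2ccc(NC(=O)CSc3nc4ccccc4s3)cc2)nc(-c2ccccc2)c1-c1ccccc1` gives 36.8%; the change from compound 1 to compound 2 is a number 8.1 percentage points lower from compound 1 to compound 2 (within the scatter), so the two numbers are not separated here. Compound 3 `Cn1nnnc1SCC(=O)Nc1ccc(-c2nc(-c3ccccc3)c(-c3ccccc3)n2C)cc1` gives 60.6%, the highest of the three numbers; its step from compound 1 is a number 15.7 percentage points higher from compound 1 to compound 3 (beyond the scatter), and from compound 2 it is a number 23.8 percentage points higher from compound 2 to compound 3 (beyond the scatter). Compound 1 thus stands second of the three, close to compound 2 and clearly under compound 3.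

The step now followed leads from compound 1 to compound 4 `Cn1ccnc1SCC(=O)Nc1ccc(-c2nc(-c3ccccc3)c(-c3ccccc3)n2C)cc1`, not yet measured in this assay. The change is 1-methyl-1H-imidazol-2-yl in place of 1,3-benzoxazol-2-yl on a sulfur. Both measured steps that exchange the benzo-fused group on the sulfur for a single five-membered ring, from compound 1 to compound 3 and from compound 2 to compound 3, went upward by a modest amount beyond the scatter. Compound 4 carries a single five-membered ring as well, so the same direction is expected, with a smaller or similar size since the two rings are not the same; the expected step is a number 9.1 percentage points higher from compound 1 to compound 4 (within the scatter). Compound 4 is therefore estimated at 54%, with a range from 40% to 68%.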

Compound 4, a percentage reported as activity, at one concentration (the size of the read-out at that concentration, not a potency): 30.7%
Estimate against measurement, compound 4: 23.3 percentage points above, outside the stated range (below it).
By their numbers in this assay, from the lowest: compounds 4, 2 and 1 (each within the scatter of the next, the first and the last beyond it); then compound 3.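

In this assay, a single five-membered ring on the sulfur does not in itself bring the upward step seen with 1-methyl-1H-tetrazol-5-yl: the exchange for 1-methyl-1H-imidazol-2-yl gives a number 14.2 percentage points lower from compound 1 to compound 4 (beyond the scatter) and so runs in the opposite direction. The two single rings are also far apart, with a number 29.9 percentage points lower from compound 3 to compound 4 (beyond the scatter) as the widest step in the set, while a number 6.1 percentage points lower from compound 2 to compound 4 (within the scatter) leaves these two compounds unseparated, so this position responds to the identity of the group on the sulfur and not simply to the loss of the fused six-membered ring. Nothing available here accounts for the split between the two single-ring groups.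

Whether compound 3 is an isolated high point or part of a wider trend remains open, as the shown groups on the sulfur are all aromatic rings. On these data alone, how a simple ethyl chain, a longer alkyl chain, or a chain ending in an amine or a carboxylic acid would read at this position also remains open.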